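Shortening the Chain on a Calcium-Flux Active Compound

The compounds below may be only part of what the source reports. "The series", "measured", "known", "first", "only" and "open" are said of these compounds alone.

Among the compounds with values here, compound 1 `CCCn1nccc1-c1ccccc1NCC1=NCCN1` holds the highest of the two numbers measured so far: in a functional assay with Alpha-1A adrenergic receptor (Homo sapiens) as the target, read by calcium flux (on this read-out higher numbers stand for larger maximal responses and lower numbers for smaller maximal responses), compound 1 gives 59%. Its nearest neighbour, compound 2 `CCn1cc(-c2ccccc2NCC2=NCCN2)cn1`, sits far lower, as in this assay compound 2 gives 0%, a gap beyond the usual scatter.

Compound 3 `Cn1nccc1-c1ccccc1NCC1=NCCN1` differs from compound 1 by hydrogen in place of ethyl on a saturated chain carbon bound to an aromatic nitrogen. Within the data shown here, no measured pair shows a step of this kind, so the outcome rests on compound 1 alone; a modest downward shift, or none beyond the scatter, is expected. The expected step of a number 9 percentage points lower from compound 1 to compound 3 (within the scatter) is small. Compound 3 is estimated to give 50%, with a range from 25% to 75%.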

Compound 3, largest response reached (reported as maximal response), in percent of the reference or control that the assay uses: 108%
Compound 3: the middle estimate sits 58 percentage points below what was measured; the measured number lies above the stated range.
By their numbers in this assay, from the lowest: compound 2; then compound 1; then compound 3.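

Cutting the chain from propyl to methyl is not a minor trim: in this assay it gives a number 49 percentage points higher from compound 1 to compound 3 (beyond the scatter). So the maximal response is sensitive to the length of this chain, and here the shorter chain gives the larger response. Nothing measured here explains this gain.

Still open, going by these compounds, is how an ethyl or a butyl chain would read at this place. Within the data shown here, with only two chain lengths compared, the response could change gradually with length or shift sharply at one particular length.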